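The source may hold more compounds than are shown below. What is called first, only, known or untested is meant among the compounds shown, and "the series" means these compounds.

Compound 1 `CCCCc1oc2ccccc2c1C(=O)c1ccc(OCC(=O)N2CCCC2)cc1`: > 50000 nM
Compound 2 `CCCCc1oc2ccccc2c1C(=O)c1ccc(OCC(=O)N2CCN(C(=O)OC(C)(C)C)CC2)cc1`: 36900 nM

In a functional assay on MDA-MB-231 cells (Homo sapiens) for antiproliferative activity, read by MTT assay, with a stated time of 24 h (on this read-out higher numbers stand for weaker inhibition and lower numbers for stronger inhibition), compound 1 gives > 50000 nM, which is a limit and not a number. For the measured compounds named here, the only true number on this scaffold so far belongs to compound 2, at 36900 nM. The next compound, compound 3 `CCCCc1oc2ccccc2c1C(=O)c1ccc(OCC(=O)Nc2cccc(OC)c2)cc1`, keeps the core of compound 1 and has (3-methoxyphenyl)amino in place of pyrrolidin-1-yl on a carbonyl carbon. Going by the values given here, no measured step between two compounds is available to serve as a guide. Compound 2, at 36900 nM, is the sole hint that a different amide group can give a readable value. The expected step of an at least 1.7-fold lower number from compound 1 to compound 3 (0.25 log units; that floor lies within the scatter) is therefore modest and towards stronger inhibition. For compound 3 the estimated value is 28000 nM, with an expected range from 9000 nM to 50000 nM.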

Compound 3, half-maximal inhibitory concentration: > 50000 nM
Compound 3 gave a limit, no number (the forecaster's own chance of this, stated with the estimate: 35%); middle value at least 1.7-fold (0.25 log units) away from the limit.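

Compound 3, like compound 1, stops at a limit and not a number in this assay, so no step between the two can be read: the limit of > 50000 nM in this assay, at which 2 of the 3 values shown sit.

The compounds shown leave open whether (3-methoxyphenyl)amino in place of pyrrolidin-1-yl changes inhibition at all.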